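The source may hold more compounds than are shown below. What is called first, only, known or untested is meant among the compounds shown, and "the series" means these compounds.

Working notes on the series. In a physicochemical assay for solubility, with a stated time of 18 h, at pH 7.4 (on this read-out lower numbers stand for lower solubility and higher numbers for higher solubility), two compounds have been measured. Compound 1 `COc1ccc(-c2ccc3c(NCCCNCc4cccc(OC)c4O)ccnc3c2)cc1` gives 32000 nM in this assay. Compound 2 `COc1ccc(F)cc1CNCCCNc1ccnc2cc(Oc3cccc(N(C)C)c3)ccc12` gives 14500 nM in this assay, the lower of the two numbers; the gap between compound 2 and compound 1 lies beyond the usual scatter. Among the compounds with values here, the two compounds differ in more than one place, so no single step can be read from them; their values show only that compound 1 sits higher.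

Compound 3 `COc1cccc(CNCCCNc2ccnc3cc(Oc4cccc(N(C)C)c4)ccc23)c1O` has not yet been measured. It differs from compound 2 by 2-hydroxy-3-methoxyphenyl in place of 5-fluoro-2-methoxyphenyl on a saturated chain carbon bound to an amine nitrogen. Within the data shown here, the group that enters is the one compound 2 lacks and compound 1 carries on the same chain position, while the rest of compound 3 stays with compound 2.

Among the measured compounds shown here, no measured step covers this change. A rise in this assay is expected for compound 3, of moderate size, because compound 1 gives 32000 nM with the same benzyl group in place. The estimated step from compound 2 to compound 3 is a 1.7-fold higher number from compound 2 to compound 3 (0.24 log units; within the scatter). For compound 3 the estimate in this assay is 25000 nM, with a range from 10000 nM to 60000 nM.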

Compound 3, solubility: 14500 nM
The estimate for compound 3 lay 1.7-fold (0.24 log units) above the measured number; low and high end bracket the measured number.
By their numbers in this assay, from the lowest: compounds 2 and 3 (each within the scatter of the next); then compound 1.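

In this assay, within the data shown here, 2-hydroxy-3-methoxyphenyl in place of 5-fluoro-2-methoxyphenyl on a saturated chain carbon bound to an amine nitrogen gives no change at the digits printed from compound 2 to compound 3 (within the scatter), the first direct reading of this position, and it shows no separation between the two groups with 3-(dimethylamino)phenoxy held constant. With the 2-hydroxy-3-methoxybenzyl group held constant, 3-(dimethylamino)phenoxy in place of 4-methoxyphenyl on an aromatic carbon gives a 2.2-fold lower number from compound 1 to compound 3 (0.34 log units; beyond the scatter), so of the two single changes now readable, only this one lies beyond the scatter. No measurement on hand bears on the reason for either step.

The compounds shown leave open whether the exchange of benzyl groups reads the same with 4-methoxyphenyl in place of 3-(dimethylamino)phenoxy, and whether the step at the aromatic carbon follows the ether oxygen or the dimethylamino group. They also leave open how an unsubstituted benzyl group, a pyridylmethyl group or a longer chain between the two amine nitrogens would read in this assay on this background.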